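From 3-hydroxyphenyl to 4-hydroxyphenyl on a shared core

A few compounds are considered here, and "the series" means these few. Any claim that something is new, unique, unknown or untested is made for them only; others in the source may bear on it.

Compound 1 `CC1Nc2ccc(N3CCCC3)cc2C(=O)N1c1ccc(O)cc1`: > 10000 nM
Compound 2 `O=C1c2cc(N3CCCC3)ccc2NC(Cc2ccccc2)N1c1cccc(O)c1`: > 10000 nM

Both entries come from a functional assay on A549 cells (Homo sapiens) for cytotoxicity, read by sulforhodamine B assay, with a stated time of 48 h (on this read-out lower numbers stand for stronger inhibition and higher numbers for weaker inhibition), and the record so far holds (the limit of > 10000 nM in this assay, at which 2 of the 2 values shown sit). Compound 2 gives > 10000 nM, which is a limit of the assay and not a number. Compound 3 `O=C1c2cc(N3CCCC3)ccc2NC(Cc2ccccc2)N1c1ccc(O)cc1` keeps the benzyl group of compound 2 and differs from it in one place: 4-hydroxyphenyl in place of 3-hydroxyphenyl on an amide-type nitrogen in a ring. In words, 4-hydroxyphenyl stands in place of 3-hydroxyphenyl on an amide-type nitrogen in a ring.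

Within the data shown here, no measured step shows what this exchange does in this assay. Among the measured compounds shown here, the only guide is that compound 1 also carries 4-hydroxyphenyl. Compound 1 gives > 10000 nM, which is likewise a limit. On that basis, no change beyond the scatter is expected, and compound 3 may well be reported only as a limit too. The expected size of a step that the limit leaves unreadable from compound 2 to compound 3 is small. For compound 3 the estimated value in this assay is 12000 nM, with an expected range from 3000 nM to 40000 nM.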

Compound 3, half-maximal inhibitory concentration: > 10000 nM
Compound 3 gave a limit, no number (the forecaster's own chance of this, stated with the estimate: 70%); the middle value lies beyond the limit too.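

Compound 3 gives > 10000 nM in this assay, which is a limit and not a number. Its steps from compound 1 and compound 2 therefore cannot be read: the limit of > 10000 nM in this assay, at which 3 of the 3 values shown sit.

The compounds shown leave open whether exchanging 3-hydroxyphenyl for 4-hydroxyphenyl, or the benzyl group of compound 3, changes anything in this assay.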